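A nitrile shift from compound 3 to compound 4

The source may hold more compounds than are shown below. What is called first, only, known or untested is meant among the compounds shown, and "the series" means these compounds.

Compound 1 `COc1cc2c(Nc3ccc(C#N)cc3)ncnc2cc1OCCCN(C)Cc1ccccc1` reaches only a limit in a functional assay on SH-SY5Y cells (Homo sapiens) for antiproliferative activity, read by MTT assay, with a stated time of 72 h (a higher number here means a weaker inhibitor, a lower number a stronger inhibitor), > 100000 nM. Compound 2 `COc1cc2c(Nc3ccc(C#N)cc3)ncnc2cc1OCCCN1CCC(O)CC1` also reaches only a limit, > 100000 nM. Compound 3 `COc1cc2c(Nc3ccc(C#N)cc3)ncnc2cc1OCCCN1CCN(C)CC1` alone gives a number, 13000 nM. Changing the group at the end of the chain gave an at least 7.6-fold lower number from compound 1 to compound 3 (0.88 log units; beyond the scatter) and an at least 7.6-fold lower number from compound 2 to compound 3 (0.88 log units; beyond the scatter), alongside a step that the two limits leave unreadable from compound 1 to compound 2.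

Compound 4 `COc1cc2c(Nc3ccccc3C#N)ncnc2cc1OCCCN1CCN(C)CC1` keeps the chain of compound 3 and differs elsewhere: 2-cyanophenyl in place of 4-cyanophenyl on a nitrogen on an aromatic ring. Here 2-cyanophenyl stands in place of 4-cyanophenyl on a nitrogen on an aromatic ring. For the measured compounds named here, none of the measured steps touches that place, so none gives a size for this change directly. Going by the values given here, compound 3, at 13000 nM, is the sole value clear of the limit of > 100000 nM in this assay, at which 2 of the 3 values shown sit, so a modest step to a higher number in this assay is expected rather than a gain. The expected change is a 1.9-fold higher number from compound 3 to compound 4 (0.28 log units; within the scatter). Compound 4 is estimated at 25000 nM, with an expected range of 8000 nM to 90000 nM.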

Compound 4, half-maximal inhibitory concentration: 32400 nM
Beside the measured number, compound 4's estimate is 1.3-fold (0.11 log units) below it; the measured number falls inside the stated range.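

In this assay, for the compounds shown here, replacing 4-cyanophenyl with 2-cyanophenyl gave a 2.5-fold higher number from compound 3 to compound 4 (0.40 log units; beyond the scatter), the first size for any change at this place, on a nitrogen on an aromatic ring. The two groups have the same atoms, joined differently, so moving the nitrile around the ring, with no atom gained or lost, is enough to shift the number beyond the scatter. With the 4-methylpiperazin-1-yl chain end kept, the shift still leaves a number clear of the limit that holds the two compounds with other chain ends: the limit of > 100000 nM in this assay, at which 2 of the 4 values shown sit.

Left open is how 3-cyanophenyl, or a phenyl ring carrying a carboxylic acid in place of the nitrile, would read at this place. Also open, from the compounds shown here alone, is whether the same shift holds with benzyl(methyl)amino or 4-hydroxypiperidin-1-yl at the chain end.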